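Swapping propyl for phenyl on a triazole side chain

The source may hold more compounds than are shown below. What is called first, only, known or untested is meant among the compounds shown, and "the series" means these compounds.

Of the compounds shown here, two have been measured in an assay on CHO cells for displacement of a labelled ligand from adenosine receptor A1 (Homo sapiens); a lower number here means a stronger inhibitor, a higher number a weaker inhibitor. Compound 1 `CCNC(=O)[C@H]1O[C@@H](n2cnc3c(NC)nc(-n4cc(Cc5ccccc5)nn4)nc32)[C@H](O)[C@@H]1O` gives 510 nM. Compound 2 `CCCCc1cn(-c2nc(NC)c3ncn([C@@H]4O[C@H](CO)[C@@H](O)[C@H]4O)c3n2)nn1` gives 848 nM, the highest of the two numbers, though its gap to compound 1 lies within the scatter, so the two cannot be ranked. Compound 3 `CNc1nc(-n2cc(Cc3ccccc3)nn2)nc2c1ncn2[C@@H]1O[C@H](CO)[C@@H](O)[C@H]1O` is not yet measured. It differs from compound 2 in one place: phenyl in place of propyl on a saturated chain carbon bound to an aromatic carbon. Going by the values given here, no step between measured compounds isolates this change, as compound 1 also carries a different group on its sugar. Since compound 1, which bears the same benzyl group, shows 510 nM, the expected step of a 1.4-fold lower number from compound 2 to compound 3 (0.15 log units; within the scatter) is small, likely a slightly lower number, and may not exceed the scatter. Compound 3 is estimated at 600 nM, with a range from 200 nM to 1800 nM.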

Compound 3, inhibition constant: 589 nM
Compound 3: the middle estimate sits 1.0-fold (0.01 log units) above what was measured, within the range that was stated.
By their numbers in this assay, from the lowest: compounds 1, 3 and 2 (each within the scatter of the next).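

In this assay, phenyl in place of propyl on a saturated chain carbon bound to an aromatic carbon, which also reads as butyl to benzyl, gives a 1.4-fold lower number from compound 2 to compound 3 (0.16 log units; within the scatter) and so this change of chain cannot be told apart from no change at all. Going by these compounds alone, the sugar can now be read on its own for the first time: with the benzyl group held fixed, hydroxymethyl in place of ethylcarbamoyl on a saturated ring carbon gives a 1.2-fold higher number from compound 1 to compound 3 (0.06 log units; within the scatter) and this swap is equally unresolved. Nothing measured here bears on what lies behind these two results.

From the compounds shown here alone, both side chains compared contain only carbon, so it remains open whether an amine, a carboxylic acid or a longer chain at this place would shift the number beyond the scatter. Going by these compounds, it is also open whether ethylcarbamoyl on the sugar would read the same alongside butyl as it does alongside benzyl.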